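Adding methoxy to compound 1

The compounds below may be only part of what the source reports. "The series", "measured", "known", "first", "only" and "open" are said of these compounds alone.

In a functional assay on HT-29 cells (Homo sapiens) for cytotoxicity, read by MTT assay, with a stated time of 24 h (on this read-out lower numbers stand for stronger inhibition and higher numbers for weaker inhibition), compound 1 (`C#CCOc1ccc(/C=N/Cc2ccc(S(N)(=O)=O)cc2)cc1`) gives 14100 nM, the lowest number among the three measured compounds, with both gaps beyond the scatter. Compound 2 (`C#CCOc1c(/C=N/Cc2ccc(S(N)(=O)=O)cc2)cccc1OC`) gives 81300 nM, and compound 3 (`C#CCOc1ccc(Br)cc1/C=N/Cc1ccc(S(N)(=O)=O)cc1`) gives 45700 nM.

Compound 4 (`C#CCOc1ccc(/C=N/Cc2ccc(S(N)(=O)=O)cc2)cc1OC`) has not yet been measured. It differs from compound 1 by methoxy in place of hydrogen on an aromatic carbon, ortho to a propargyloxy group and meta to a large group. Going by the values given here, no measured pair isolates this change, so the evidence is indirect. Compound 2 also carries a methoxy and stands at 81300 nM, a higher number than that of compound 1, but its groups are not arranged as in compound 4.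

A modest move toward weaker inhibition in this assay is therefore expected, with an estimated step of a 2.3-fold higher number from compound 1 to compound 4 (0.36 log units; beyond the scatter). The estimate for compound 4 is 32000 nM, with an expected range of 12000 nM to 85000 nM.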

Compound 4, half-maximal inhibitory concentration: 136000 nM
The estimate for compound 4 lay 4.3-fold (0.63 log units) below the measured number; the measured number lies above the stated range.
By their numbers in this assay, from the lowest: compound 1; then compounds 3, 2 and 4 (each within the scatter of the next, the first and the last beyond it).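

Methoxy in place of hydrogen on an aromatic carbon, ortho to a propargyloxy group and meta to a large group, now has a direct reading in this assay, with a 9.6-fold higher number from compound 1 to compound 4 (0.98 log units; beyond the scatter), a move toward weaker inhibition. On the core of compound 1, this position is therefore not indifferent to substitution, since an entering group of 2 heavy atoms gives a step beyond the scatter. Nothing measured on these compounds explains the size of this step.

Open, going by these compounds, is whether fluorine, hydroxyl or an amine at this same position would give a step of similar size. Also open, on these data alone, is whether methoxy elsewhere on the ring would behave the same way, as compound 2 has its groups arranged differently and does not isolate that change.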